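The source may hold more compounds than are shown below. What is called first, only, known or untested is meant among the compounds shown, and "the series" means these compounds.

Compound 1 `CC(O)(COc1cccc(C(F)(F)F)c1)C(=O)Nc1cccc(S(F)(F)(F)(F)F)c1`: 22500 nM
Compound 2 `CC(O)(COc1ccccc1C(F)(F)F)C(=O)Nc1cccc(S(F)(F)(F)(F)F)c1`: 36700 nM
Compound 3 `CC(O)(COc1ccc(C#N)cc1)C(=O)Nc1cccc(S(F)(F)(F)(F)F)c1`: 26600 nM

These readings come from a functional assay on VCaP cells (Homo sapiens) for antiproliferative activity, read by propidium iodide staining, with a stated time of 96 h; a lower number here means a stronger inhibitor, a higher number a weaker inhibitor. The three compounds share a core and differ only in the substituted phenyl on an oxygen. Compound 3 stands within the scatter of both the others, with a 1.2-fold higher number from compound 1 to compound 3 (0.07 log units; within the scatter) and a 1.4-fold lower number from compound 2 to compound 3 (0.14 log units; within the scatter). The remaining step, a 1.6-fold higher number from compound 1 to compound 2 (0.21 log units; within the scatter), is also within the scatter, so these numbers do not separate the three compounds.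

Compound 4 `CC(O)(COc1ccc(C#N)c(F)c1)C(=O)Nc1cccc(S(F)(F)(F)(F)F)c1` differs from compound 3 in one place: fluoro in place of hydrogen on an aromatic carbon. This is fluoro in place of hydrogen on an aromatic carbon, ortho to a cyano group, which turns 4-cyanophenyl into 4-cyano-3-fluorophenyl. Among the compounds with values here, no measured step makes this exact change, so the evidence is indirect. Even the full exchanges of the phenyl substituent, such as a 1.2-fold higher number from compound 1 to compound 3 (0.07 log units; within the scatter), stayed within the scatter. A step beyond the scatter in this assay is therefore not expected, and no direction is favoured. The estimate stays anchored on compound 3 at 26600 nM. The expected change is a 1.1-fold lower number from compound 3 to compound 4 (0.03 log units; within the scatter). Compound 4 is expected to read about 25000 nM, with an estimated range from 12000 nM to 50000 nM.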

Compound 4, half-maximal inhibitory concentration: 91900 nM
Estimate against measurement, compound 4: 3.7-fold (0.57 log units) below; measured number outside the range, above it.
By their numbers in this assay, from the lowest: compounds 1, 3 and 2 (each within the scatter of the next); then compound 4.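

In this assay, a single fluoro on an aromatic carbon, ortho to a cyano group, proved enough to move the reading (a 3.5-fold higher number from compound 3 to compound 4 (0.54 log units; beyond the scatter)), whereas the exchanges among the three earlier phenyl substituents had all stayed within the scatter. Compound 4 also stands apart from the two trifluoromethyl compounds (a 2.5-fold higher number from compound 2 to compound 4 (0.40 log units; beyond the scatter); a 4.1-fold higher number from compound 1 to compound 4 (0.61 log units; beyond the scatter)), which makes it the weakest of the four and shows that this series can respond to a change on the phenyl ring, even though this rests on one fluoro pair and all four compounds remain weak inhibitors. Nothing given here bears on why this one added atom changes the number.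

On these data alone, it remains open whether the step belongs to fluoro itself or to any group at this position, since a chloro, a methyl, a methoxy or an amine on the same carbon would be needed to tell these apart. As far as these compounds go, it is also open whether fluoro would do the same on the rings of compound 1 and compound 2, or on the 4-cyanophenyl ring at the other carbon ortho to the oxygen.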